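The source may report more compounds than this note shows. Statements on the series, on what has been measured and on what is new or still open speak of the compounds shown alone.

Working notes on the series. In a functional assay on A549 cells (Homo sapiens) for antiproliferative activity, read by MTT assay, with a stated time of 48 h (a higher number here means a weaker inhibitor, a lower number a stronger inhibitor), compound 1 `Cc1cccc(-n2nncc2CN2C(=O)C3(C(C#N)=C(N)Oc4c(N)cc5nc6ccccc6nc5c43)c3ccccc32)c1` gives 12300 nM. Compound 3 `N#CC1=C(N)Oc2c(N)cc3nc4ccccc4nc3c2C12C(=O)N(Cc1cnnn1-c1cccc(C(F)(F)F)c1)c1ccccc12` gives 5400 nM in this assay, the lowest of the two numbers; its nearest neighbour is compound 1, the gap being a 2.3-fold lower number from compound 1 to compound 3 (0.36 log units; beyond the scatter). Compound 2 `N#CC1=C(N)Oc2c(N)cc3nc4ccccc4nc3c2C12C(=O)N(Cc1cnnn1-c1ccc(Cl)cc1)c1ccccc12` reaches only a limit, > 50000 nM, in this assay; see (the limit of > 50000 nM in this assay, at which 1 of the 3 values shown sits). The 4-chlorophenyl brought an at least 4.0-fold higher number from compound 1 to compound 2 (0.60 log units; beyond the scatter) and, reversed, an at least 9.2-fold lower number from compound 2 to compound 3 (0.96 log units; beyond the scatter). Compound 4 `N#CC1=C(N)Oc2c(N)cc3nc4ccccc4nc3c2C12C(=O)N(Cc1cnnn1-c1ccc([N+](=O)[O-])cc1)c1ccccc12` differs from compound 3 by 4-nitrophenyl in place of 3-(trifluoromethyl)phenyl on an aromatic nitrogen. Among the measured compounds shown here, a 4-nitrophenyl, like the 4-chlorophenyl of compound 2, bears on the only steps to hand, so an at least modest rise is expected, a 4.6-fold higher number from compound 3 to compound 4 (0.67 log units; beyond the scatter). Compound 4 is therefore estimated at 25000 nM in this assay, within 8000 nM to 80000 nM, with a fair chance of a limit only.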

Compound 4, half-maximal inhibitory concentration: > 50000 nM
Compound 4: only a limit was reported; the forecaster's own chance of this, stated with the estimate: 30%; at least 2.0-fold (0.30 log units) between middle value and limit.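

With the 4-nitrophenyl on the aromatic nitrogen, the series shows an at least 9.2-fold higher number from compound 3 to compound 4 (0.96 log units; beyond the scatter) and an at least 4.0-fold higher number from compound 1 to compound 4 (0.60 log units; beyond the scatter). Among the four compounds, the 4-chlorophenyl and 4-nitrophenyl both give higher numbers than the 3-methylphenyl and 3-(trifluoromethyl)phenyl, and none goes against this. The step between compound 2 and compound 4 cannot be read, as both values are limits: the limit of > 50000 nM in this assay, at which 2 of the 4 values shown sit.

As far as these compounds go, whether the place on the phenyl ring or the group itself decides this remains open. A 3-nitrophenyl and a 4-methylphenyl would separate the two, while an aminophenyl or unsubstituted phenyl remains unplaced.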